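The source may hold more compounds than are shown below. What is called first, only, known or untested is meant among the compounds shown, and "the series" means these compounds.

Working notes on the series. All three measured compounds share one core, differing only in the group on the carbonyl carbon of the amide. In a functional assay on SW1573 cells (Homo sapiens) for cytotoxicity, read by sulforhodamine B assay, with a stated time of 72 h (a lower number here means a stronger inhibitor, a higher number a weaker inhibitor), compound 1 `CC(=O)Nc1ccn([C@@H]2CO[C@H](CO)O2)c(=O)n1` gives 10700 nM, compound 2 `CCCCC(=O)Nc1ccn([C@@H]2CO[C@H](CO)O2)c(=O)n1` gives 9130 nM, and compound 3 `O=C(Nc1ccn([C@@H]2CO[C@H](CO)O2)c(=O)n1)C1CC1` gives 22000 nM. Compound 3 stands with the highest number of the three: its nearest neighbour is compound 1, its most distant compound 2. The steps of a 2.1-fold higher number from compound 1 to compound 3 (0.31 log units; beyond the scatter) and a 2.4-fold higher number from compound 2 to compound 3 (0.38 log units; beyond the scatter) are both modest but beyond the scatter, whereas a 1.2-fold lower number from compound 1 to compound 2 (0.07 log units; within the scatter) lies within it.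

Compound 4 `O=C(Nc1ccn([C@@H]2CO[C@H](CO)O2)c(=O)n1)C1CCCCC1` differs from compound 3 by cyclohexyl in place of cyclopropyl on a carbonyl carbon. For the measured compounds named here, no measured step exchanges one ring for another on this carbonyl carbon; the closest information is that compound 3 sits higher than compound 1 and compound 2, and that a chain extension in a 1.2-fold lower number from compound 1 to compound 2 (0.07 log units; within the scatter) left the number essentially unchanged. A step of no more than modest size is therefore expected in this assay, with the direction uncertain. The estimate for compound 4 is 16000 nM, within 5000 nM to 50000 nM, meaning an expected 1.4-fold lower number from compound 3 to compound 4 (0.14 log units; within the scatter).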

Compound 4, half-maximal inhibitory concentration: 14000 nM
The estimate for compound 4 lay 1.1-fold (0.06 log units) above the measured number; the measured number falls inside the stated range.
By their numbers in this assay, from the lowest: compounds 2, 1, 4 and 3 (each within the scatter of the next, the first and the last beyond it).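

In this assay cyclohexyl on the carbonyl carbon cannot be separated from cyclopropyl (a 1.6-fold lower number from compound 3 to compound 4 (0.20 log units; within the scatter)), butyl (a 1.5-fold higher number from compound 2 to compound 4 (0.19 log units; within the scatter)) or methyl (a 1.3-fold higher number from compound 1 to compound 4 (0.12 log units; within the scatter)). The separation of compound 3 from compound 1 and compound 2 is therefore not shared by compound 4, so carrying a non-aromatic carbon ring at this position does not by itself mark a compound out from those with open chains, and the widest step among these four compounds remains modest (a 2.4-fold higher number from compound 2 to compound 3 (0.38 log units; beyond the scatter)). Nothing in hand bears on why the numbers fall as they do.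

Going by these compounds, whether an amine, a carboxylic acid, a phenyl ring or a chain longer than butyl on this carbonyl carbon would move the number further remains open. On these data alone, the contribution of the shared core also stays open: all four compounds carry it unchanged.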